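Pyridin-4-yl to pyridin-3-yl on the carbonyl carbon

The source may hold more compounds than are shown below. What is called first, only, known or untested is meant among the compounds shown, and "the series" means these compounds.

Of the compounds shown here, three on a shared core have been measured in an assay on CHO cells for displacement of a labelled ligand from adenosine receptor A1 (Homo sapiens), read by scintillation counting, with a stated time of 120 min, tested at 1 uM; a higher number here means more inhibition at the concentration tested (going by the name of the read-out), a lower number less inhibition. Compound 1 `Cc1nc(NC(=O)Nc2ccccc2)c2nn(-c3ccccc3)cc2n1` gives 1%. Compound 2 `Cc1nc(NC(=O)c2ccco2)c2nn(-c3ccccc3)cc2n1` gives 20%, and compound 3 `Cc1nc(NC(=O)c2ccncc2)c2nn(-c3ccccc3)cc2n1` gives 12%. The change furan-2-yl in place of anilino on a carbonyl carbon gives a number 19 percentage points higher from compound 1 to compound 2 (beyond the scatter), and the change pyridin-4-yl in place of anilino on a carbonyl carbon gives a number 11 percentage points higher from compound 1 to compound 3 (beyond the scatter). Between the two aromatic amides, a number 8 percentage points lower from compound 2 to compound 3 (within the scatter). Compound 3 therefore stands second highest of the three numbers, separated from compound 2 by a gap within the scatter and from compound 1 by a gap beyond it.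

Compound 4 `Cc1nc(NC(=O)c2cccnc2)c2nn(-c3ccccc3)cc2n1` differs from compound 3 in one place: pyridin-3-yl in place of pyridin-4-yl on a carbonyl carbon. Among the measured compounds shown here, no measured step exchanges one six-membered aromatic group for another; the nearest comparison is the step within the scatter between compound 2 and compound 3, two different aromatic amides on the same core. No step beyond the scatter is therefore expected in this assay. The estimate for compound 4 is 14%, with a range from 3% to 30%. This corresponds to an expected step of a number 2 percentage points higher from compound 3 to compound 4 (within the scatter).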

Compound 4, a percentage reported as inhibition, at one concentration (the size of the read-out at that concentration, not a potency): 12%
Compound 4: the middle estimate sits 2 percentage points above what was measured; the measured number falls inside the stated range.
By their numbers in this assay, from the lowest: compound 1; then compounds 3, 4 and 2 (each within the scatter of the next).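

Exchanging pyridin-4-yl for pyridin-3-yl on a carbonyl carbon whose other neighbour is an amide-type nitrogen gives no change at the digits printed from compound 3 to compound 4 (within the scatter) in this assay. Among the compounds shown here, this is the first pair with the same atoms joined differently, and at the single concentration tested the read-out does not separate these two pyridine attachments. The result also extends the earlier picture to a third aromatic amide, with a number 11 percentage points higher from compound 1 to compound 4 (beyond the scatter), alongside a number 11 percentage points higher from compound 1 to compound 3 (beyond the scatter) and a number 19 percentage points higher from compound 1 to compound 2 (beyond the scatter), while a number 8 percentage points lower from compound 2 to compound 4 (within the scatter) leaves the furan-2-yl and pyridin-3-yl amides unseparated, and nothing at hand gives a reason for this result.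

From the compounds shown here alone, it remains open whether a pyridin-2-yl group, a plain phenyl ring or a piperidine joined through its nitrogen on the same carbonyl carbon would stand apart from these amides. These readings at one concentration also leave open whether compound 2, compound 3 and compound 4 would differ at other concentrations, or in any other assay.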